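Fluoro for methoxy at the assay limit

A few compounds are considered here, and "the series" means these few. Any claim that something is new, unique, unknown or untested is made for them only; others in the source may bear on it.

In an ADME assay on SH-SY5Y cells (Homo sapiens) for cytotoxicity, read by MTT assay, with a stated time of 72 h (a lower number here means a stronger inhibitor, a higher number a weaker inhibitor), compound 1 (`COc1ccc2[nH]cc(CCCN3CCN(C(=O)CN4CCN(C(=O)c5cccc(Cl)c5)CC4)CC3)c2c1`) gives > 200000 nM as a limit of the assay and not a number. In this assay compound 2 (`COc1cccc(C(=O)N2CCN(CC(=O)N3CCN(CCCc4c[nH]c5ccc(OC)cc45)CC3)CC2)c1`) gives > 200000 nM as a limit as well, so its place is known only as a limit. Among the measured compounds shown here, the one measured step bearing on the next change is a step that the two limits leave unreadable from compound 1 to compound 2 and it supplies no size. For the measured compounds named here, the series so far stands at the limit of > 200000 nM in this assay, at which 2 of the 2 values shown sit, and offers no graded value. Compound 3 (`COc1ccc2[nH]cc(CCCN3CCN(C(=O)CN4CCN(C(=O)c5cccc(F)c5)CC4)CC3)c2c1`) follows from compound 2 by fluoro in place of methoxy on an aromatic carbon with fluoro in place of methoxy on an aromatic carbon, meta to a large group. Since compound 2 rests at > 200000 nM as a limit, no step beyond the scatter is expected and no direction can be given. The expected step is a number no higher from compound 2 to compound 3 (the limit leaves the size open) and it stays an estimate tied to that limit. Compound 3 is estimated at 200000 nM with an expected range from 100000 nM to 400000 nM and a report as a limit is the likeliest outcome.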

Compound 3, half-maximal inhibitory concentration: > 200000 nM
Compound 3 was reported as a limit (the forecaster's own chance of this, stated with the estimate: 85%); the middle value lies on the limit itself.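

No step can be read between compound 1, compound 2 and compound 3 in this assay, as each result is only a limit: the limit of > 200000 nM in this assay, at which 3 of the 3 values shown sit.

The compounds shown leave open whether the chloro, methoxy and fluoro analogues differ at all in cytotoxicity, and which change to the shared core would give a graded value.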